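The source may hold more compounds than are shown below. What is called first, only, known or untested is meant among the compounds shown, and "the series" means these compounds.

In a functional assay on DWD cells (Homo sapiens) for inhibition, read by sulforhodamine B assay (on this read-out lower numbers stand for stronger inhibition of growth and higher numbers for weaker inhibition of growth), three compounds on a shared core have been measured so far. Compound 1 (`c1ccc(-c2ccc(-c3ccc(-c4nc5ccccc5[nH]4)cc3)cc2)cc1`) gives 100000 nM as the highest number of the three. Compound 2 (`Oc1cccc2[nH]c(-c3ccc(-c4ccc(-c5ccccc5)cc4)cc3)nc12`) gives 9680 nM as the lowest. Compound 3 (`Cc1ccc2[nH]c(-c3ccc(-c4ccc(-c5ccccc5)cc4)cc3)nc2c1`) gives 28300 nM and so stands second highest, between the other two.

Compound 4 (`Cc1ccc2[nH]c(-c3ccc(-c4ccc(-c5ccc(O)cc5)cc4)cc3)nc2c1`) differs from compound 3 in one place (hydroxy in place of hydrogen on an aromatic carbon), with hydroxy in place of hydrogen on an aromatic carbon, which turns phenyl into 4-hydroxyphenyl.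

Among the measured compounds shown here, two measured steps bear on this change. The nearer in kind, a 10-fold lower number from compound 1 to compound 2 (1.01 log units; beyond the scatter) and large, also puts hydroxy in place of hydrogen, though at another place in the molecule. The second, a 3.5-fold lower number from compound 1 to compound 3 (0.55 log units; beyond the scatter) and modest, brings in the methyl that compound 4 keeps. For the measured compounds named here, no measured pair shows hydroxy at the place it takes in compound 4, so the large step cannot simply be carried over. A lower number is expected in this assay but a smaller drop than that large one. The expected change is a 3.1-fold lower number from compound 3 to compound 4 (0.50 log units; beyond the scatter) and it carries wide margins. For compound 4 the estimated value is 9000 nM (expected range 2500 nM to 28000 nM).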

Compound 4, concentration for 50% growth inhibition: 21200 nM
Beside the measured number, compound 4's estimate is 2.4-fold (0.37 log units) below it; the measured number falls inside the stated range.
By their numbers in this assay, from the lowest: compound 2; then compounds 4 and 3 (each within the scatter of the next); then compound 1.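

In this assay, hydroxy in place of hydrogen on the aromatic carbon para to a large group, the change that turns phenyl into 4-hydroxyphenyl, gives a 1.3-fold lower number from compound 3 to compound 4 (0.13 log units; within the scatter), so at this position the change gives a step that cannot be told from the scatter. Among the compounds shown here, until now the only reading of hydroxy on these compounds was a large one, a 10-fold lower number from compound 1 to compound 2 (1.01 log units; beyond the scatter), at another place in the molecule, and that step can no longer stand for hydroxy in general. Set side by side, the two readings of the same change do not agree: the same change on two cores in this assay, a 10-fold lower number (1.01 log units; beyond the scatter) from compound 1 to compound 2 and a 1.3-fold lower number (0.13 log units; within the scatter) from compound 3 to compound 4, 7.7-fold (0.89 log units) apart, beyond the scatter of two such steps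

The compounds shown leave open whether this gap follows the place of the hydroxy or the methyl that the second pair carries, as the two steps differ in both and no pair separates them. They also leave open whether another group at this position, such as an amine or a carboxylic acid, would give a step beyond the scatter in this assay.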